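A few compounds are considered here, and "the series" means these few. Any claim that something is new, unique, unknown or untested is made for them only; others in the source may bear on it.

Measured compounds:
Compound 1, `CS(=O)(=O)Nc1ccccc1-c1ccc(COC2CC[C@H](N3CCCCCC3)[C@H]2OC/C=C\CCC(=O)O)cc1`, gives 10 nM in a functional assay on blood for antagonist activity at thromboxane A2 receptor (Homo sapiens); a higher number here means weaker binding, a lower number tighter binding.
Compound 2, `O=C(O)CC/C=C\CO[C@H]1[C@@H](OCc2ccc(-c3ccccc3)cc2)CC[C@@H]1N1CCCCCC1`, gives 5.01 nM in this assay.
Compound 3, `O=C(O)CC/C=C\CO[C@H]1C(OCc2ccc(-c3ccc(CO)cc3)cc2)CC[C@@H]1N1CCCCCC1`, gives 3.16 nM in this assay.

Compound 3 stands lowest of the three numbers in this assay. Its nearest neighbour is compound 2, whose number is within the scatter of compound 3, so the two cannot be ordered; compound 1 lies furthest, and the step of a 3.2-fold lower number from compound 1 to compound 3 (0.50 log units; beyond the scatter) is beyond the scatter. Compound 4, `O=C(O)CC/C=C\CO[C@H]1[C@@H](OCc2ccc(-c3ccc(CO)cc3)cc2)CC[C@@H]1N1CCCCCC1`, differs from compound 3 only in this respect: the two compounds have the same atoms and bonds; at least one stereo element is drawn with a configuration in one of them and without one in the other: 1 of 4 stereo elements differ; a stereocentre at a saturated ring carbon is drawn without a configuration in compound 3 and S in compound 4. Within the data shown here, no measured step covers a change of drawn configuration alone; the one step that is measured, from compound 1 to compound 3, concerns a different part of the molecule and does not bear on this change. Compound 2 carries the same fully drawn configuration as compound 4 and sits within the scatter of compound 3. Compound 4 is therefore expected to give a number close to compound 3, with the step of a 1.3-fold lower number from compound 3 to compound 4 (0.10 log units; within the scatter) estimated to stay within the scatter. The estimate for compound 4 in this assay is 2.5 nM, in the range 1 nM to 8 nM.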

Compound 4, dissociation constant: 3.98 nM
Estimate against measurement, compound 4: 1.6-fold (0.20 log units) below, within the range that was stated.
By their numbers in this assay, from the lowest: compounds 3, 4, 2 and 1 (each within the scatter of the next, the first and the last beyond it).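

In this assay, drawing the saturated ring carbon as S rather than without a configuration gives a 1.3-fold higher number from compound 3 to compound 4 (0.10 log units; within the scatter) and so shows no change that can be told apart at this position. The step compares a defined drawing with an undefined one, not two opposite configurations, because of this: the fact that one of compounds 3 and 4 is drawn with a defined configuration and the other without, at the place where they differ. With that configuration drawn in both compounds, hydroxymethyl in place of hydrogen on an aromatic carbon gives a 1.3-fold lower number from compound 2 to compound 4 (0.10 log units; within the scatter) and so shows that, in this assay, the group makes no difference that can be told apart from hydrogen.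

Going by these compounds, what the opposite configuration at this ring carbon would give remains open. So does whether a carboxylic acid or an amine in place of hydroxymethyl on that aromatic carbon would move the number beyond the scatter.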